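The compounds below may be only part of what the source reports. "The series", "measured", "known", "first", "only" and "open" are said of these compounds alone.

In a physicochemical assay for solubility, in phosphate buffer, measured as kinetic solubility, with a stated time of 1 h, at pH 7.4 (on this read-out higher numbers stand for higher solubility and lower numbers for lower solubility), compound 2 `COc1ccc2nc(C)cc(OCC(=O)NCc3cc(C)cc(C)c3)c2c1` stands highest of the three numbers with 92000 nM. Compound 3 `COc1ccc2nc(C)cc(OCC(=O)Nc3cc(OC)c(OC)c(OC)c3)c2c1`, which also carries an aryl group directly on its amide nitrogen, gives 34000 nM in this assay, a reading beyond the scatter below compound 2. Compound 1 `COc1ccc2nc(C)c(NC(=O)C(=O)Nc3cc(C)cc(C)c3)c(O)c2c1`, the oxalamide, gives 10000 nM in this assay, the lowest of the three and furthest from compound 2.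

Compound 4 `COc1ccc2nc(C)cc(OCC(=O)Nc3cc(C)nc(C)n3)c2c1` has not yet been measured. It differs from compound 2 in one place: 2,6-dimethylpyrimidin-4-yl in place of 3,5-dimethylbenzyl on an amide-type nitrogen. Within the data shown here, no step between measured compounds matches this change, so the expectation rests on the neighbours only. Among the measured compounds shown here, compound 3 shows that an aryl group set straight on the amide nitrogen sits below compound 2 in this assay, while the added ring nitrogens in compound 4 have no measured counterpart here.

On balance compound 4 is expected to land close to compound 2, with the step of a 1.5-fold lower number from compound 2 to compound 4 (0.19 log units; within the scatter) estimated as a modest move downward, likely within or near the scatter. The estimate for compound 4 in this assay is 60000 nM, with a range from 20000 nM to 150000 nM.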

Compound 4, solubility: 5000 nM
Estimate against measurement, compound 4: 12-fold (1.08 log units) above; measured number below the stated range.
By their numbers in this assay, from the lowest: compounds 4 and 1 (each within the scatter of the next); then compound 3; then compound 2.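

Exchanging 3,5-dimethylbenzyl for 2,6-dimethylpyrimidin-4-yl on the amide-type nitrogen gives, in this assay, an 18-fold lower number from compound 2 to compound 4 (1.26 log units; beyond the scatter). Among these compounds, this is the only step in the set that isolates this position, and it shows that the read-out can move far there even though the entering and leaving groups each hold one six-membered aromatic ring and neither carries a net charge. Nothing measured here accounts for the size of this step.

The change combines two differences, the ring nitrogens and the loss of the benzyl carbon link, and the compounds shown do not separate them. From the compounds shown here alone, how a 2,6-dimethylpyridin-4-yl group or a (2,6-dimethylpyrimidin-4-yl)methyl group on the same nitrogen would read remains open.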